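From 3-methoxyphenyl to 4-fluorophenyl: working notes on the series

The source may report more compounds than this note shows. Statements on the series, on what has been measured and on what is new or still open speak of the compounds shown alone.

Measured in a physicochemical assay, with a stated time of 6 min; a higher number here means a weaker inhibitor, a lower number a stronger inhibitor:
- Compound 1 `O=C(Nc1nc(-c2cc3cc(Br)ccc3o2)cs1)Nc1ccccc1F`: > 200000 nM (a limit)
- Compound 2 `COc1ccc(NC(=O)Nc2nc(-c3cc4cc(Br)ccc4o3)cs2)cc1`: > 200000 nM (a limit)
- Compound 3 `COc1cccc(NC(=O)Nc2nc(-c3cc4cc(Br)ccc4o3)cs2)c1`: > 200000 nM (a limit)

Compound 3 gives only a limit, > 200000 nM. The next change leads to compound 4 `O=C(Nc1ccc(F)cc1)Nc1nc(-c2cc3cc(Br)ccc3o2)cs1`, with 4-fluorophenyl in place of 3-methoxyphenyl on an amide-type nitrogen.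

Going by the values given here, three measured steps bear on this change: a step that the two limits leave unreadable from compound 1 to compound 2, a step that the two limits leave unreadable from compound 1 to compound 3 and a step that the two limits leave unreadable from compound 2 to compound 3. Their sizes cannot be read because of the limit of > 200000 nM in this assay, at which 3 of the 3 values shown sit. Compound 1, with 2-fluorophenyl on the amide-type nitrogen, also gives only a limit, > 200000 nM.

No step beyond the scatter is therefore expected in this assay, and the data support no direction. The expected step is a number no higher from compound 3 to compound 4 (the limit leaves the size open). For compound 4 the estimate is 200000 nM, with an expected range of 70000 nM to 400000 nM. A further limit is the most likely result.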

Compound 4, half-maximal inhibitory concentration: > 200000 nM
Compound 4: only a limit was reported; the forecaster's own chance of this, stated with the estimate: 80%; the middle value lies on the limit itself.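

In this assay compound 4 gives the limit > 200000 nM and, as with compound 1, compound 2 and compound 3, no step among these compounds can be read: the limit of > 200000 nM in this assay, at which 4 of the 4 values shown sit.

The compounds shown leave open how the aromatic groups on the amide-type nitrogen rank against one another.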